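Two Aryl Ether Ketones at the Assay Limit and a Cyclohexyl Analogue

The compounds below may be only part of what the source reports. "The series", "measured", "known", "first", "only" and "open" are said of these compounds alone.

Measured so far:
Compound 1 `CC(C)=CCOc1cccc(O)c1C(=O)/C=C/c1ccc(O)cc1`: > 30000 nM
Compound 2 `CC(C)(C)CCOc1cccc(O)c1C(=O)CCc1ccc(O)cc1`: > 30000 nM

In an assay on THP-1 cells for inhibition of nuclear factor NF-kappa-B complex (Homo sapiens), with stated times of 2 h and 16 h (on this read-out lower numbers stand for stronger inhibition and higher numbers for weaker inhibition), compound 1 gives > 30000 nM, which is a limit of the assay rather than a number. In this assay compound 2 gives > 30000 nM, again a limit. Going by the values given here, both measured values therefore sit at the limit of > 30000 nM in this assay, at which 2 of the 2 values shown sit, so compound 1 stands nowhere within the measurable range, and no step between the two compounds can be sized.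

Compound 3 `O=C(/C=C/c1ccc(O)cc1)c1c(O)cccc1OCCC1CCCCC1` has not yet been measured in this assay. It differs from compound 1 in one place: cyclohexylmethyl in place of 2-methylprop-1-en-1-yl on a saturated chain carbon bound to an oxygen on an aromatic ring. Nothing measured distinguishes the two ether chains that have been tested, since both gave only a limit. The step from compound 1 to compound 3 is therefore expected to be a step that the limit leaves unreadable from compound 1 to compound 3, none beyond the scatter. Compound 3 is estimated at 50000 nM, with a range from 15000 nM to 200000 nM, and most likely only a limit will be reported.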

Compound 3, half-maximal inhibitory concentration: > 30000 nM
Compound 3 was reported as a limit; the forecaster's own chance of this, stated with the estimate: 80%; the middle value does not contradict the limit.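

In this assay compound 3 gives > 30000 nM and this is a limit of the assay, not a number. No step can be read between compound 1 and compound 3: the limit of > 30000 nM in this assay, at which 3 of the 3 values shown sit. The compounds shown leave open whether any ether chain on the shared core would give a measurable value in this assay at all.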